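This account rests on a few compounds, and the source may have more. Where it says the series, first, only, none or still open, it means among the compounds named here.

Measured compounds:
compound 1 `COc1ccc(C2CC(c3ccc4ccccc4c3)=NN2C2=NC(=O)/C(=C3\C(=O)Nc4ccccc43)S2)cc1`, in a functional assay on cells (Cancer cell lines, Homo sapiens) for cytotoxicity, read by sulforhodamine B assay, with a stated time of 48 h (on this read-out lower numbers stand for stronger inhibition of growth and higher numbers for weaker inhibition of growth), compound 1 gives 12600 nM
compound 2 `O=C1N=C(N2N=C(c3ccccc3)CC2c2ccc(Cl)cc2)S/C1=C1/C(=O)Nc2ccccc21`, compound 2 gives 500 nM
compound 3 `COc1ccc(C2=NN(C3=NC(=O)/C(=C4\C(=O)Nc5ccccc54)S3)C(c3ccc(Cl)cc3)C2)cc1`, compound 3 gives 100000 nM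

Compound 3 stands highest of the three, so it is the weakest growth inhibitor shown. The change to compound 4 `O=C1N=C(N2N=C(c3ccc4ccccc4c3)CC2c2ccc(Cl)cc2)S/C1=C1/C(=O)Nc2ccccc21` is naphthalen-2-yl in place of 4-methoxyphenyl on a carbon with a double bond to nitrogen. For the measured compounds named here, no measured step makes exactly this change. Going by the values given here, the one step that bears on it, a 200-fold higher number from compound 2 to compound 3 (2.30 log units; beyond the scatter), shows that the methoxy-bearing ring was linked to a large rise in the number. Compound 4 removes that ring, so a large drop is expected, though the entering naphthalen-2-yl has no single-change comparison; compound 1, which carries it alongside the methoxyphenyl, sits between the others. The expected step is a 67-fold lower number from compound 3 to compound 4 (1.82 log units; beyond the scatter). Compound 4 is therefore estimated at 1500 nM, within 300 nM to 8000 nM.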

Compound 4, concentration for total growth inhibition: 27300 nM
Compound 4: middle estimate off by 18-fold (1.26 log units), on the low side; measured number outside the range, above it.
By their numbers in this assay, from the lowest: compound 2; then compound 1; then compound 4; then compound 3.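

In this assay, phenyl remains the best of the three groups tested at this position with the 4-chlorophenyl group kept in place: naphthalen-2-yl gives a 55-fold higher number from compound 2 to compound 4 (1.74 log units; beyond the scatter). Replacing 4-methoxyphenyl with naphthalen-2-yl recovers only part of the loss, with a 3.7-fold lower number from compound 3 to compound 4 (0.56 log units; beyond the scatter). The group on the other ring also counts, since with naphthalen-2-yl present, chloro in place of methoxy gives a 2.2-fold higher number from compound 1 to compound 4 (0.34 log units; beyond the scatter).

Nothing available explains these differences. As far as these compounds go, whether a phenyl ring carrying an amine or a carboxylic acid would match compound 2 remains open.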